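The source may report more compounds than this note shows. Statements on the series, on what has been measured and on what is new or still open speak of the compounds shown alone.

In a functional assay on the whole organism (strain Swiss) with Mus musculus as the target, in the maximal electroshock model, with a stated time of 1 h, at a dose of 300 mg/kg by the intraperitoneal route (a lower number here means a weaker effect, a higher number a stronger effect of the compound at the dose given), compound 1 `CCC(C(=O)N1CCN(c2cccc(Cl)c2)CC1)N1C(=O)CCC1=O` gives 100%, the highest of the three numbers measured. Compound 2 `CC(C(=O)N1CCN(c2cccc(Cl)c2)CC1)N1C(=O)CCC1=O` gives 75%, and compound 3 `CC(C(=O)N1CCN(c2ccc(F)cc2)CC1)N1C(=O)CCC1=O` gives 25%. The step of a number 25 percentage points lower from compound 1 to compound 2 (beyond the scatter) came with hydrogen in place of methyl on a saturated chain carbon, two bonds along the chain from an amide-type nitrogen in a ring and a carbonyl carbon. The step of a number 50 percentage points lower from compound 2 to compound 3 (beyond the scatter) came with 4-fluorophenyl in place of 3-chlorophenyl on an amine nitrogen in a ring. Compound 4 `CCC(C(=O)N1CCN(c2ccccc2Cl)CC1)N1C(=O)CCC1=O` differs from compound 1 by 2-chlorophenyl in place of 3-chlorophenyl on an amine nitrogen in a ring. Because a number 50 percentage points lower from compound 2 to compound 3 (beyond the scatter) also altered the group on that amine nitrogen and was large, a smaller downward step is expected here, estimated at a number 25 percentage points lower from compound 1 to compound 4 (beyond the scatter). Compound 4 is estimated to give 75%, within 40% to 100%.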

Compound 4, a percentage reported as activity, at one dose (the size of the read-out at that dose, not a potency): 50%
For compound 4 the middle estimate is 25 percentage points above the measured one; measured number inside the range.
By their numbers in this assay, from the lowest: compound 3; then compound 4; then compound 2; then compound 1.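

In this assay, putting 2-chlorophenyl in place of 3-chlorophenyl gives a number 50 percentage points lower from compound 1 to compound 4 (beyond the scatter). The earlier change on this ring nitrogen altered the halogen and its place on the phenyl ring together, whereas here the atoms stay the same and only the place of the chlorine moves, so place alone can change this read-out strongly. Nothing measured here explains this drop.

As far as these compounds go, how 4-chlorophenyl or unsubstituted phenyl on this nitrogen would compare with 3-chlorophenyl remains open. So does whether a 3-methoxyphenyl group could match it.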